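This account rests on a few compounds, and the source may have more. Where it says the series, first, only, none or still open, it means among the compounds named here.

Two ureas have so far been measured in an ADME assay for permeability, using PAMPA, at pH 7.4; on this read-out higher numbers stand for higher permeability and lower numbers for lower permeability. Compound 1, with the structure `Cc1cc(NC(=O)Nc2ccc(C)c(Cl)c2)c2ccccc2n1`, gives 262 10^-6 cm/s in this assay. Compound 2, with the structure `Cc1cc(NC(=O)Nc2ccccc2C(F)(F)F)c2ccccc2n1`, gives 945 10^-6 cm/s in this assay. Compound 2 thus stands at the higher of the two numbers, and the gap between compound 1 and compound 2 is beyond the usual scatter of repeated measurements.

The next compound, compound 3, has the structure `CSc1ccccc1NC(=O)Nc1cc(C)nc2ccccc12`. It differs from compound 2 in one place: methylsulfanyl in place of trifluoromethyl on an aromatic carbon. Within the data shown here, no pair of measured compounds differs by exactly this exchange, so there is no measured step to lean on; the expectation rests on the number of compound 2 alone.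

Both groups are small, uncharged and carry no hydrogen-bond donor, so the expected step from compound 2 to compound 3 in this assay is a 1.3-fold lower number from compound 2 to compound 3 (0.10 log units; within the scatter), which is none beyond the scatter. On that basis compound 3 is estimated to give 750 10^-6 cm/s in this assay, with a range from 380 10^-6 cm/s to 1300 10^-6 cm/s.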

Compound 3, apparent permeability: 1260 10^-6 cm/s
Compound 3: the middle estimate sits 1.7-fold (0.23 log units) below what was measured; the range from low to high includes it.
By their numbers in this assay, from the lowest: compound 1; then compounds 2 and 3 (each within the scatter of the next).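

Exchanging trifluoromethyl for methylsulfanyl on an aromatic carbon, ortho to a large group, gives a 1.3-fold higher number from compound 2 to compound 3 (0.12 log units; within the scatter) in this assay, so on this read-out the two compounds cannot be told apart. Among these compounds, this is the first measured step at this position, and it shows that a group of 4 heavy atoms with no hydrogen-bond acceptor can give way to one of 2 heavy atoms with 1 hydrogen-bond acceptor, with no difference that stands clear of the scatter of repeated measurements. No measurement at hand bears on what lies behind this result.

Among the compounds shown here, with only this one exchange at this position, it remains open whether a charged or hydrogen-bond-donating group, such as an amine or a carboxylic acid, or a longer chain such as ethylsulfanyl, would also stay level with these two compounds. On these data alone, it also remains open whether the same exchange would give a similar step on another aromatic carbon or on a different core.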